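The source may report more compounds than this note shows. Statements on the series, on what has been measured and on what is new or still open speak of the compounds shown alone.

Measured in a functional assay on microsomes for inhibition, with a stated time of 1 h; a lower number here means a stronger inhibitor, a higher number a weaker inhibitor:
- Compound 1 `COc1ccc(-c2nc(NN)n(C)c(=O)c2C#N)cc1`: 39 ug/mL
- Compound 2 `CCOC(=O)c1cnn(-c2nc(-c3ccccc3F)c(C#N)c(=O)n2C)c1N`: 94 ug/mL
- Compound 3 `CCOC(=O)c1cnn(-c2nc(-c3cccc(OC)c3OC)c(C#N)c(=O)n2C)c1N`: 57 ug/mL

Compound 3 gives 57 ug/mL, a number within the usual scatter of both neighbouring results, since compound 1 gives 39 ug/mL and compound 2 gives 94 ug/mL. The next compound to be tested is compound 4 `CCOC(=O)c1cnn(-c2nc(-c3ccco3)c(C#N)c(=O)n2C)c1N`. It carries furan-2-yl in place of 2,3-dimethoxyphenyl on an aromatic carbon. That carbon lies next to the ring nitrogen and ortho to a cyano group.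

Among the compounds with values here, one measured step bears on this place: a 1.6-fold lower number from compound 2 to compound 3 (0.22 log units; within the scatter), which stays within the scatter. It exchanges 2-fluorophenyl for 2,3-dimethoxyphenyl, so both of its groups are six-membered aromatic rings of carbon only. Within the data shown here, no measured compound has a five-membered aromatic ring here, so the data offer no direct reading on furan-2-yl and the expectation remains loose. Among the measured compounds shown here, no step beyond the scatter is expected in this assay because a 1.6-fold lower number from compound 2 to compound 3 (0.22 log units; within the scatter) is the only measured guide at this place, and neither direction is favoured. The expected step is a 1.1-fold higher number from compound 3 to compound 4 (0.06 log units; within the scatter). For compound 4 the estimated value is 65 ug/mL, with an expected range from 30 ug/mL to 140 ug/mL.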

Compound 4, half-maximal inhibitory concentration: 116 ug/mL
For compound 4 the middle estimate is 1.8-fold (0.25 log units) below the measured one, within the range that was stated.
By their numbers in this assay, from the lowest: compounds 1, 3, 2 and 4 (each within the scatter of the next, the first and the last beyond it).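

In this assay, within the data shown here, this aromatic carbon, ortho to a cyano group, now carries a five-membered aromatic ring with 1 hetero atom, and furan-2-yl in place of 2,3-dimethoxyphenyl gives a 2.0-fold higher number from compound 3 to compound 4 (0.31 log units; beyond the scatter), the first step at this place that lies beyond the scatter, though only modestly. Furan-2-yl in place of 2-fluorophenyl gives a 1.2-fold higher number from compound 2 to compound 4 (0.09 log units; within the scatter), so the change of ring size alone does not separate these two groups, and compound 2 stays within the scatter of both compound 3 and compound 4, which leaves only the two ends of this short series apart. Nothing measured here accounts for the difference between the furan-2-yl and 2,3-dimethoxyphenyl compounds.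

As far as these compounds go, the compounds compared at this place all carry an aromatic ring there, so how an amine or a longer alkyl chain on this carbon would read in this assay remains open. From the compounds shown here alone, it is also open whether a thiophene or a pyridine ring would fall with furan-2-yl or with 2,3-dimethoxyphenyl.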